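Moving the methoxy on the aryl group: compound 4

This account rests on a few compounds, and the source may have more. Where it says the series, first, only, none or still open, it means among the compounds named here.

Three sulfones sharing one core have been run in an ADME assay on microsomes from liver (Homo sapiens) for metabolic stability, tested at 2.5 uM; a lower number here means slower removal, a higher number faster removal of the compound. Compound 1 `O=S(=O)(c1ccc(F)cc1)c1cnc2c(F)cccc2c1-c1cccc(F)c1` gives 1.56 mL/min in this assay, compound 2 `COc1ccc(-c2c(S(=O)(=O)c3ccc(OC)cc3)cnc3c(F)cccc23)cc1` gives 2.12 mL/min, and compound 3 `COc1cccc(-c2c(S(=O)(=O)c3ccc(F)cc3)cnc3c(F)cccc23)c1` gives 2.23 mL/min. The three numbers lie close together; compound 3 sits alongside compound 2 and compound 1, and none of the gaps exceeds the usual scatter, so no ordering can be read from them. Among the compounds with values here, the one single-point step in the set, a 1.4-fold higher number from compound 1 to compound 3 (0.16 log units; within the scatter), is itself within the scatter.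

Compound 4 `COc1ccc(-c2c(S(=O)(=O)c3ccc(F)cc3)cnc3c(F)cccc23)cc1` has not been measured in this assay. It differs from compound 3 by 4-methoxyphenyl in place of 3-methoxyphenyl on an aromatic carbon. Within the data shown here, no measured step covers this rearrangement: compound 2 carries the 4-methoxyphenyl group but differs from compound 4 elsewhere as well, so its value set against that of compound 3 shows only that the two lie within the scatter of each other. Among the measured compounds shown here, the only step that bears at all is the exchange from compound 1 to compound 3, which stayed within the scatter; the shift from 3-methoxyphenyl to 4-methoxyphenyl is expected to do no more. The expected step is a 1.1-fold lower number from compound 3 to compound 4 (0.03 log units; within the scatter), nothing beyond the scatter. Compound 4 is expected to give 2.1 mL/min in this assay, within a range from 1.3 mL/min to 3.4 mL/min.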

Compound 4, intrinsic clearance in a liver preparation (reported as CLH), per the amount of preparation that the assay uses: 2.41 mL/min
Estimate against measurement, compound 4: 1.1-fold (0.06 log units) below; the range from low to high includes it.
By their numbers in this assay, from the lowest: compounds 1, 2, 3 and 4 (each within the scatter of the next).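

Working notes: the position opposite the ring nitrogen now has a direct pair in this assay, and the placement of the methoxy on the aryl group there makes no readable difference (a 1.1-fold higher number from compound 3 to compound 4 (0.03 log units; within the scatter)). The wider exchange at this position, 4-methoxyphenyl in place of 3-fluorophenyl, also stays inside the scatter (a 1.5-fold higher number from compound 1 to compound 4 (0.19 log units; within the scatter)), as does the exchange of methoxy for fluoro on the aryl group of the sulfone (a 1.1-fold higher number from compound 2 to compound 4 (0.06 log units; within the scatter)). Methoxy in place of fluoro can now be read on two cores, and the two readings show no shared direction and no effect that can be separated from the scatter: the same change on two cores in this assay, a 1.4-fold higher number (0.16 log units; within the scatter) from compound 1 to compound 3 and a 1.1-fold lower number (0.06 log units; within the scatter) from compound 4 to compound 2, 1.6-fold (0.21 log units) apart, within the scatter of two such steps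

All four compounds carry only fluoro or methoxy on these two aryl groups, so the series so far spans a narrow set of substituents, and no group shown here moves the clearance beyond the scatter. Open, going by these compounds, is whether an amine, a carboxylic acid or a longer alkoxy chain on the aryl group at this position would give a number that can be told apart from those of compounds 1 to 4.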